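Dibutylamino to dipentylamino on the shared core

The source may report more compounds than this note shows. Statements on the series, on what has been measured and on what is new or still open speak of the compounds shown alone.

Values in a functional assay on LNCaP cells (Homo sapiens) for antiproliferative activity, read by WST assay, with a stated time of 3 days (on this read-out lower numbers stand for stronger inhibition and higher numbers for weaker inhibition), so far:

- compound 1 `CCCCCOc1c(-c2cc(OC)c(OC)c(OC)c2)oc2ccccc2c1=O` reads 15400 nM
- compound 2 `CCCCN(CCCC)CCCCCOc1c(-c2cc(OC)c(OC)c(OC)c2)oc2ccccc2c1=O` reads 7800 nM

Compound 2 stands within the scatter of compound 1, so the two numbers do not separate. Compound 3 `CCCCCN(CCCCC)CCCCCOc1c(-c2cc(OC)c(OC)c(OC)c2)oc2ccccc2c1=O` differs from compound 2 by one change (dipentylamino in place of dibutylamino on a saturated chain carbon, five bonds along the chain from an oxygen on an aromatic ring), dipentylamino in place of dibutylamino on a saturated chain carbon, five bonds along the chain from an oxygen on an aromatic ring. Among the measured compounds shown here, the one measured step that bears on it, a 2.0-fold lower number from compound 1 to compound 2 (0.30 log units; within the scatter), put dibutylamino in place of hydrogen at that same place. For the measured compounds named here, no measured step varies the chains on the amine. Starting from compound 2 at 7800 nM, no step beyond the scatter is expected in this assay, in either direction. The expected step is a 1.2-fold lower number from compound 2 to compound 3 (0.08 log units; within the scatter) and remains an estimate. Compound 3 is estimated at 6500 nM (expected range 2800 nM to 15000 nM).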

Compound 3, half-maximal inhibitory concentration: 7900 nM
Estimate against measurement, compound 3: 1.2-fold (0.08 log units) below; the range from low to high includes it.
By their numbers in this assay, from the lowest: compounds 2, 3 and 1 (each within the scatter of the next).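

In this assay, dipentylamino in place of dibutylamino gives a 1.0-fold higher number from compound 2 to compound 3 (0.01 log units; within the scatter), so these two amines do not separate on a saturated chain carbon, five bonds along the chain from an oxygen on an aromatic ring. Measured against the hydrogen of compound 1, dipentylamino gives a 1.9-fold lower number from compound 1 to compound 3 (0.29 log units; within the scatter), so this second amine, like dibutylamino, does not separate from hydrogen at this place. No evidence is available that bears on these readings.

The compounds shown leave open whether a smaller amine such as dimethylamino, or a ring amine such as piperidine or morpholine, would read apart from these compounds at this place. They also leave open whether a shorter or longer chain between the oxygen and the amine nitrogen would do so.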